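The source may report more compounds than this note shows. Statements on the series, on what has been measured and on what is new or still open speak of the compounds shown alone.

Compound 1 `O=C(N[C@@H]1C(=O)N(c2ccccc2)C[C@@H]1C(=O)O)c1ccc2ccccc2c1` is the stronger of the two numbered compounds in an assay on cell membranes for displacement of a labelled ligand from Cholecystokinin receptor type A (Rattus norvegicus), read by radioligand binding (a higher number here means a weaker inhibitor, a lower number a stronger inhibitor), where compound 1 gives 16 nM. Compound 2 `O=C(N[C@H]1C(=O)N(c2ccccc2)C[C@@H]1C(=O)O)c1ccc2ccccc2c1` is its partner with one stereocentre drawn differently; in this assay compound 2 gives 290 nM, and the step of an 18-fold higher number from compound 1 to compound 2 (1.26 log units; beyond the scatter). Compound 3 `O=C(O)[C@H]1CN(c2ccccc2)C(=O)[C@H]1NS(=O)(=O)c1ccc2ccccc2c1` reaches only a limit of the assay: in this assay compound 3 gives >> 1000 nM. Compound 4 `CC(C)(C)OC(=O)[C@H]1CN(c2ccccc2)C(=O)[C@H]1NC(=O)c1ccc2ccccc2c1` carries tert-butyl in place of hydrogen on an oxygen next to a carbonyl group. Within the data shown here, no measured step alters this group, so the only known step, between configurations, does not bear directly on it; the expectation is therefore cautious, with a step of a 13-fold higher number from compound 1 to compound 4 (1.10 log units; beyond the scatter) estimated. For compound 4 the estimate in this assay is 200 nM, expected between 30 nM and 2000 nM.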

Compound 4, half-maximal inhibitory concentration: >> 1000 nM
Compound 4 gave a limit, no number; the forecaster's own chance of this, stated with the estimate: 20%; middle value at least 5.0-fold (0.69 log units) from the limit.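

Among these compounds, no earlier measured step touched the carboxy group of compound 1, and changing it to tert-butoxycarbonyl proves costly, with an at least 62-fold higher number from compound 1 to compound 4 (1.79 log units; beyond the scatter). In this assay compound 4 gives >> 1000 nM, which is a limit of the assay and not a number, so this step fixes only a minimum size. This position therefore tolerates at least this one change poorly.

The compounds shown cannot separate losing the hydrogen from adding the tert-butyl group. A methyl ester or a primary amide at this position would help tell the two apart.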